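This account rests on a few compounds, and the source may have more. Where it says the series, first, only, none or still open, it means among the compounds named here.

In a functional assay on HepG2 cells (Homo sapiens) for antiproliferative activity, read by MTT assay, with a stated time of 48 h (a lower number here means a stronger inhibitor, a higher number a weaker inhibitor), compound 1 `CCn1c(C(=O)N(CCC#N)CCC#N)ccc1C(CC)(CC)c1ccc(OCCC(O)(CC)CC)c(C)c1` gives 46300 nM as its half-maximal inhibitory concentration. Compound 2 `C=CCN(C)C(=O)c1ccc(C(CC)(CC)c2ccc(OCCC(O)(CC)CC)c(C)c2)n1CC` gives > 50000 nM in the same test, and this is a limit of the assay, not a number. Within the data shown here, the only measured step is an at least 1.0-fold higher number from compound 1 to compound 2 (0.03 log units; that floor lies within the scatter) and it lies within the scatter, so swapping one ring-free group on the carbonyl carbon for another shows no real change. Compound 3 `CCn1c(C(=O)Nc2ccc(OC(F)(F)F)cc2)ccc1C(CC)(CC)c1ccc(OCCC(O)(CC)CC)c(C)c1` differs from compound 2 by a larger exchange, (4-(trifluoromethoxy)phenyl)amino in place of allyl(methyl)amino on a carbonyl carbon with (4-(trifluoromethoxy)phenyl)amino in place of allyl(methyl)amino on a carbonyl carbon. This brings in a six-membered aromatic ring of carbon only, which neither measured compound has there, so the measured step is a weak guide. Among the measured compounds shown here, compound 1 at 46300 nM is the only true number to lean on, so only a modest change is expected. The estimated step is an at least 2.0-fold lower number from compound 2 to compound 3 (0.30 log units; that floor lies within the scatter) in the direction of a lower number. Compound 3 is estimated at 25000 nM with a likely range from 7000 nM to 50000 nM in this test.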

Compound 3, half-maximal inhibitory concentration: > 50000 nM
Compound 3: no number, only a limit (the forecaster's own chance of this, stated with the estimate: 40%); middle value at least 2.0-fold (0.30 log units) away from the limit.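

In this assay compound 3 gives > 50000 nM, which is a limit of the assay and not a number. Even with a six-membered aromatic ring and a hydrogen-bond donor on the carbonyl carbon, features absent from the ring-free groups before it, the comparison with the only true number shows an at least 1.0-fold higher number from compound 1 to compound 3 (0.03 log units; that floor lies within the scatter), while the step between the two limits cannot be read. This position has now taken three quite different groups without a value clearly lower than that of compound 1, but the ceiling of the test restricts what can be read: the limit of > 50000 nM in this assay, at which 2 of the 3 values shown sit.

From the compounds shown here alone, whether any group on this carbonyl carbon can give a clearly lower number remains open. A simple morpholine amide or a carboxylic acid in this place would test that, and a number rather than a limit would make such steps readable.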